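The compounds below may be only part of what the source reports. "The series", "measured", "known", "first", "only" and "open" are said of these compounds alone.

In a functional assay on Jurkat cells (Homo sapiens) for inhibition, read by MTT assay, with a stated time of 72 h (a lower number here means a stronger inhibitor, a higher number a weaker inhibitor), compound 2 (`C=C(Br)C(=O)Nc1cccc(/C=C/C(=O)Nc2ccccc2)c1`) gives 5000 nM, and this sits at the upper end of what has been measured so far. Compound 1 (`COc1cc(NC(=O)/C=C/c2cccc(OCc3ccccc3)c2)cc(OC)c1OC`) gives 3500 nM, which lies within the usual scatter of the figure for compound 2, so the two cannot be told apart on these numbers. Compound 3 (`C=C(Br)C(=O)Nc1cccc(/C=C/C(=O)Nc2cccc3ccccc23)c1`) gives 680 nM, a clearly lower number, with a gap to compound 2 that lies beyond the scatter.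

The next compound to be tested is compound 4 (`C=C(Br)C(=O)Nc1cccc(/C=C/C(=O)Nc2ccc(F)cc2)c1`). Its structure departs from that of compound 2 in one place: fluoro in place of hydrogen on an aromatic carbon. In plain terms, the phenyl of compound 2 becomes 4-fluorophenyl in compound 4.

For the measured compounds named here, none of the measured compounds forms a pair that differs in one place, so the data offer no direct measure of what this change does. The expectation is therefore modest: no shift beyond the scatter in this assay, with at most a slight lean towards a lower number. The estimated change is a 1.4-fold lower number from compound 2 to compound 4 (0.15 log units; within the scatter). For compound 4 the expected value is 3500 nM, with an estimated range of 1500 nM to 8000 nM.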

Compound 4, half-maximal inhibitory concentration: 6200 nM
For compound 4 the middle estimate is 1.8-fold (0.25 log units) below the measured one; low and high end bracket the measured number.
By their numbers in this assay, from the lowest: compound 3; then compounds 1, 2 and 4 (each within the scatter of the next).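

In this assay, for the compounds shown here, the replacement of phenyl by 4-fluorophenyl gives the first direct reading of a single change in this set: fluoro in place of hydrogen on an aromatic carbon, para to a large group, amounts to a 1.2-fold higher number from compound 2 to compound 4 (0.09 log units; within the scatter), a step within the scatter. Going by these compounds alone, on these numbers, compound 2 and compound 4 cannot be told apart, so this one replacement at this position has no effect that the assay can resolve, a point that the earlier compounds, with no single-place pair among them, could not address. No supporting measurement bears on why the step is so small, and this single pair cannot show whether the same would hold elsewhere in the series.

Going by these compounds, it remains open whether a different group at this same position, such as chloro, methoxy, an amine or a carboxylic acid, would move the number beyond the scatter. Also open, on these data alone, is whether fluoro on another carbon of this ring, or the same replacement tested on a cell type other than the one used here, would give a similarly small step.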